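The source may report more compounds than this note shows. Statements on the series, on what has been measured and on what is new or still open speak of the compounds shown alone.

Working notes on the trimethoxyphenyl triazole series.

Compound 1 `COc1cc(-c2ncnn2-c2cccc(N)c2)cc(OC)c1OC` carries a 3-aminophenyl on an aromatic nitrogen of the shared core. In a functional assay on HeLa cells (Homo sapiens) for antiproliferative activity, read by MTT assay, with a stated time of 72 h (a lower number here means a stronger inhibitor, a higher number a weaker inhibitor), compound 1 gives > 10000 nM, which is a limit of the assay and not a number. Compound 2 `COc1ccc(-n2ncnc2-c2cc(OC)c(OC)c(OC)c2)cc1` carries a 4-methoxyphenyl instead. In this assay compound 2 gives > 10000 nM, again a limit. Compound 3 `COc1cc(-c2ncnn2-c2ccc(F)cc2)cc(OC)c1OC` carries a 4-fluorophenyl. In this assay compound 3 gives > 10000 nM, also a limit, so compound 3 stands at the same boundary as the other two rather than at a known point.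

Compound 4 `COc1cc(-c2ncnn2-c2ccc(N)cc2)cc(OC)c1OC` differs from compound 3 only by amino in place of fluoro on an aromatic carbon.

The measured steps offer no readable size: a step that the two limits leave unreadable from compound 1 to compound 2, a step that the two limits leave unreadable from compound 1 to compound 3 and a step that the two limits leave unreadable from compound 2 to compound 3 all run between limits. Within the data shown here, what the series does show is the limit of > 10000 nM in this assay, at which 3 of the 3 values shown sit: every value so far sits at that boundary, whatever the group on the aromatic nitrogen. Among the measured compounds shown here, no step shows that swapping one small group on that phenyl for another moves the value away from the limit, so the expectation for compound 4 is the same boundary, and a step that the limit leaves unreadable from compound 3 to compound 4 is expected only nominally.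

For compound 4 in this assay an inhibitory concentration of 15000 nM is estimated, within 5000 nM to 60000 nM, most likely reported as a limit.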

Compound 4, half-maximal inhibitory concentration: > 10000 nM
Compound 4 gave a limit, no number (the forecaster's own chance of this, stated with the estimate: 80%); the middle value does not contradict the limit.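

With compound 4 now a limit as well, no step among compounds 1, 2, 3 and 4 can be read in this assay, since each runs between limits: the limit of > 10000 nM in this assay, at which 4 of the 4 values shown sit.

What the compounds shown leave open is how far each lies beyond that boundary, and whether any group on that phenyl changes the value at all.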